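A few compounds are considered here, and "the series" means these few. Any claim that something is new, unique, unknown or untested is made for them only; others in the source may bear on it.

Working notes on the series. Compound 1 `CC(C)C[C@H](N)CN(C(=O)C(C)Cc1ccccc1)c1ccc(-c2ccccc2)cc1` is the reference point here: in a functional assay for agonist activity at G protein-coupled receptor 88 (Homo sapiens), read by HTRF and cAMP accumulation (a higher number here means that more compound is needed for the effect, a lower number that less compound is needed), compound 1 gives 1.2 nM. Compound 2 `CC[C@H](C)[C@H](N)CN(C(=O)[C@@H]1C[C@H]1c1ccc(F)c(F)c1)c1ccc(-c2ccccc2)cc1`, carrying a cyclopropyl amide and a shortened side chain, gives 720 nM in this assay. Compound 3 `CC(C)C[C@H](N)CN(C(=O)[C@@H]1C[C@H]1c1ccccc1)c1ccc(-c2cccnc2)cc1` carries the cyclopropyl amide of compound 2 but a pyridin-3-yl distal ring. In this assay compound 3 gives 10000 nM, the highest of the three values; compound 2 stands nearest to it and compound 1 furthest, both gaps beyond the scatter.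

Compound 4 `CC(C)C[C@H](N)CN(C(=O)[C@@H]1C[C@H]1c1ccccc1)c1ccc(-c2cccc(F)c2)cc1` differs from compound 3 in one place: 3-fluorophenyl in place of pyridin-3-yl on an aromatic carbon. The change brings the distal ring back toward the carbon-only aromatic found in compound 1 and compound 2, both of which show lower values than compound 3. On that basis the step from compound 3 to compound 4 is expected to be a drop in this assay of the order a 25-fold lower number from compound 3 to compound 4 (1.40 log units; beyond the scatter), though the pairing with the cyclopropyl amide seen in compound 2 argues against reaching the level of compound 1. Compound 4 is therefore estimated at 400 nM, within 60 nM to 3000 nM.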

Compound 4, half-maximal effective concentration: 2100 nM
Compound 4: middle estimate off by 5.3-fold (0.72 log units), on the low side; the range from low to high includes it.
By their numbers in this assay, from the lowest: compound 1; then compound 2; then compound 4; then compound 3.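

In this assay, among the compounds shown here, exchanging pyridin-3-yl for 3-fluorophenyl on an aromatic carbon, para to a large group, gives a 4.8-fold lower number from compound 3 to compound 4 (0.68 log units; beyond the scatter), the only step so far that isolates this position. The step is modest but shows that the distal ring alone moves the value with the rest of the molecule held constant, even though compound 4 still stands at 2100 nM. No measurement at hand bears on the cause of this step.

The exchange removes the ring nitrogen and adds a fluorine in a single move, so the compounds shown do not separate the contribution of each. From the compounds shown here alone, how a methoxy group or a nitrile would read at this position on the same amide also remains open.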